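This account rests on a few compounds, and the source may have more. Where it says the series, first, only, none or still open, it means among the compounds named here.

Measured compounds and values in an ADME assay on HEK293 cells (Homo sapiens) for cytotoxicity, read by resazurin assay, with a stated time of 48 h; a higher number here means that more compound is tolerated, a lower number that less compound is tolerated:

- compound 1 `O=S(=O)(Nc1ccc(-c2nc3ccccc3o2)cc1)c1cccc(O)c1`: > 100000 nM
- compound 2 `COc1cccc(S(=O)(=O)Nc2ccc3oc(-c4ccccc4)nc3c2)c1`: 63000 nM

The value of compound 1 is not a number but a limit of this assay, the highest concentration that was tested. Among the compounds with values here, compound 2 is therefore the only compound here with a measured number in this assay, and the other value is a limit; so there is no measured step to compare it with.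

Compound 3 `O=S(=O)(Nc1ccc2oc(-c3ccccc3)nc2c1)c1ccc(O)cc1` has not yet been measured. It differs from compound 2 in one place: 4-hydroxyphenyl in place of 3-methoxyphenyl on a sulfonyl sulfur. Within the data shown here, both changes are small exchanges at the ring on the sulfonyl sulfur, and the only other compound with a hydroxyphenyl there, compound 1, sits at the limit of > 100000 nM in this assay, at which 1 of the 2 values shown sits. Among the measured compounds shown here, with no measured step to lean on, the expectation for compound 3 in this assay is a step of a 1.3-fold higher number from compound 2 to compound 3 (0.10 log units; within the scatter), which is no change beyond the usual scatter. Compound 3 is thus estimated at 80000 nM, with a likely range from 30000 nM to 200000 nM, and a fair chance that this assay again reports only a limit.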

Compound 3, half-maximal cytotoxic concentration: > 100000 nM
Compound 3: no number, only a limit (the forecaster's own chance of this, stated with the estimate: 40%); at least 1.2-fold (0.09 log units) between middle value and limit.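

Within the data shown here, the exchange of 3-methoxyphenyl for 4-hydroxyphenyl on a sulfonyl sulfur is the first step that can be read in this assay, and it gives an at least 1.5-fold higher number from compound 2 to compound 3 (0.20 log units; that floor lies within the scatter). As far as these compounds go, compound 3 gives > 100000 nM, which is a limit and not a number, so only a floor is known for this step and its true size remains unknown. What this adds is that the exchange at this place brings no fall in the number, and the upper end of the tested range now holds most of the values shown: the limit of > 100000 nM in this assay, at which 2 of the 3 values shown sit.

The step combines two differences in one change, the kind of oxygen group on the ring and where it sits, and the compounds shown do not separate them. From the compounds shown here alone, it also remains open whether a different group on that ring, such as an amine or a carboxylic acid, would give a measured number in this assay rather than another limit.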